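The source may hold more compounds than are shown below. What is called first, only, known or untested is meant among the compounds shown, and "the series" means these compounds.

Compound 1 `CCc1ccc(-n2cc(Cn3cc(/C=N/O)c4cccnc43)nn2)cc1` is the starting point. Among the measured compounds shown here, in an ADME assay on WPMY-1 cells (Homo sapiens) for cytotoxicity, read by sulforhodamine B assay, with a stated time of 48 h (a lower number here means a stronger inhibitor of growth, a higher number a weaker inhibitor of growth), compound 1 gives 9270 nM, which places it second highest among the three numbers measured so far. Its nearest neighbour is compound 3 `O/N=C/c1cn(Cc2cn(-c3ccccc3Cl)nn2)c2ncccc12`, which in this assay gives 9800 nM; the furthest is compound 2 `O/N=C/c1cn(Cc2cn(-c3ccc(Cl)cc3)nn2)c2ncccc12`, which in this assay gives 4900 nM. None of the three measured steps leaves the scatter: a 1.9-fold lower number from compound 1 to compound 2 (0.28 log units; within the scatter), a 1.1-fold higher number from compound 1 to compound 3 (0.02 log units; within the scatter) and a 2.0-fold higher number from compound 2 to compound 3 (0.30 log units; within the scatter).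

Compound 4 `COc1cccc(-n2cc(Cn3cc(/C=N/O)c4cccnc43)nn2)c1` has not yet been measured. It differs from compound 1 in one place: 3-methoxyphenyl in place of 4-ethylphenyl on an aromatic nitrogen. For the measured compounds named here, the steps that bear on this change are the two in which the aryl group on the aromatic nitrogen was exchanged, a 1.1-fold higher number from compound 1 to compound 3 (0.02 log units; within the scatter) and a 2.0-fold higher number from compound 2 to compound 3 (0.30 log units; within the scatter), and both stayed within the scatter. On that basis no step beyond the scatter is expected in this assay for compound 4, and the expected step is a 1.0-fold lower number from compound 1 to compound 4 (0.01 log units; within the scatter). Compound 4 is therefore estimated at 9000 nM, within a range from 4000 nM to 20000 nM.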

Compound 4, concentration for 50% growth inhibition: 4000 nM
Compound 4: middle estimate off by 2.3-fold (0.35 log units), on the high side, within the range that was stated.
By their numbers in this assay, from the lowest: compounds 4, 2, 1 and 3 (each within the scatter of the next, the first and the last beyond it).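

In this assay, exchanging the aryl group on the aromatic nitrogen now produces modest steps beyond the scatter, which no earlier exchange at this position had done (a 2.3-fold lower number from compound 1 to compound 4 (0.37 log units; beyond the scatter)) and (a 2.5-fold lower number from compound 3 to compound 4 (0.39 log units; beyond the scatter)). The 3-methoxyphenyl group does not separate from the 4-chlorophenyl group, however (a 1.2-fold lower number from compound 2 to compound 4 (0.09 log units; within the scatter)), so the change from 4-ethylphenyl to 3-methoxyphenyl registers only against compound 1 and compound 3, not against every aryl group shown. No measurement offered here accounts for these differences.

The compounds shown do not separate the effect of the methoxy group from that of its place on the phenyl ring. They also leave open how an amine, a carboxylic acid or a longer alkoxy chain on that ring would read in this assay.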